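Swapping the Five-Membered Ring on the Amide Side Chain

The compounds below may be only part of what the source reports. "The series", "measured", "known", "first", "only" and "open" are said of these compounds alone.

The measured compounds:
Compound 1 `CCN(Cc1cccn1C)C(=O)COc1ccc(C)cc1` gives 21300 nM in an assay on HEK293 cells for agonist activity at transient receptor potential cation channel subfamily M member 8 (Homo sapiens), read by fluorescence and calcium flux, with a stated time of 15 min; on this read-out lower numbers stand for an effect already at smaller amounts and higher numbers for an effect only at larger amounts of compound.
Compound 2 `CCN(Cc1ccco1)C(=O)COc1ccc(C)cc1` gives 489 nM in this assay.
Compound 3 `CCN(Cc1cccs1)C(=O)COc1ccc(F)cc1` gives 422 nM in this assay.

Compound 2 stands second highest of the three numbers. Its nearest neighbour is compound 3, which gives 422 nM in this assay, within the scatter of compound 2, while compound 1 lies far away above it. Among the compounds with values here, the one single-point step that is known, a 44-fold lower number from compound 1 to compound 2 (1.64 log units; beyond the scatter), concerns the same position but a different exchange.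

Compound 4 `CCN(Cc1ccsc1)C(=O)COc1ccc(C)cc1` has not yet been measured. Its difference from compound 2 is thiophen-3-yl in place of furan-2-yl on a saturated chain carbon bound to an amide-type nitrogen. Within the data shown here, no measured step changes furan-2-yl into thiophen-3-yl, so that step in this assay has to be judged without a direct precedent. Compound 3 differs from compound 2 in two places and is not a single-point comparison, but its value shows that a compound in this family carrying a thiophene ring can sit close to compound 2. The expectation for compound 4 is therefore a step of a 1.0-fold higher number from compound 2 to compound 4 (0.01 log units; within the scatter) in this assay, within the scatter. Compound 4 is estimated at 500 nM, with a range from 150 nM to 1700 nM.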

Compound 4, half-maximal effective concentration: 88 nM
Compound 4: middle estimate off by 5.7-fold (0.75 log units), on the high side, and the stated range ends above it.
By their numbers in this assay, from the lowest: compound 4; then compounds 3 and 2 (each within the scatter of the next); then compound 1.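

In this assay, the ring on the saturated chain carbon bound to an amide-type nitrogen matters even when the exchange looks small: thiophen-3-yl in place of furan-2-yl gives a 5.6-fold lower number from compound 2 to compound 4 (0.74 log units; beyond the scatter) although both are five-membered aromatic rings with 1 hetero atom. With the rest of the structure unchanged, the exchange of 1-methyl-1H-pyrrol-2-yl for thiophen-3-yl gives a 240-fold lower number from compound 1 to compound 4 (2.38 log units; beyond the scatter), so this position alone spans a wide range of values. Nothing measured here explains these differences.

The step from furan-2-yl to thiophen-3-yl changes both the hetero atom and the ring carbon that carries the chain, so the compounds shown cannot separate these two changes. A furan-3-yl group on the same core would help to tell them apart, and a phenyl ring at this position remains an open case.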